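A few compounds are considered here, and "the series" means these few. Any claim that something is new, unique, unknown or untested is made for them only; others in the source may bear on it.

Measured compounds:
- Compound 1 `CC(C)C[C@@H]1NC(=O)[C@H](CCCNC(=N)N)NC(=O)[C@H](CCCCN)NC(=O)[C@H](CC(=O)O)NC(=O)[C@H](CCCCN)NC(=O)[C@H](CO)NC1=O`: 240 nM
- Compound 2 `CC(C)C[C@@H]1NC(=O)[C@H](CCCNC(=N)N)NC(=O)[C@H](CCCCN)NC(=O)[C@H](CC(=O)O)NC(=O)[C@H](CCCCN)NC(=O)CCNC1=O`: 1650 nM

Compound 1 and compound 2 were both tested in an assay on COS-7 cells for inhibition of disintegrin and metalloproteinase domain-containing protein 8 (Homo sapiens), read by ELISA, with a stated time of 6 h; on this read-out lower numbers stand for stronger inhibition and higher numbers for weaker inhibition. In this assay compound 1 gives 240 nM, while compound 2 gives 1650 nM, which is the higher of the two numbers; the gap between them lies beyond the usual scatter of repeated measurements. For the measured compounds named here, compound 2 therefore stands as the weaker of the two measured cyclic peptides, with compound 1 as its only neighbour.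

Compound 3 `CC(C)C[C@@H]1NC(=O)[C@H](CCCNC(N)=O)NC(=O)[C@H](CCCCN)NC(=O)[C@H](CC(=O)O)NC(=O)[C@H](CCCCN)NC(=O)CCNC1=O` has not been measured in this assay. It differs from compound 2 in a single place: a group of 3 heavy atoms (1 carbon, 1 nitrogen, 1 oxygen; no ring) in place of a group of 3 heavy atoms (1 carbon, 2 nitrogen; no ring), on an amine nitrogen, that is, a carbamoyl group in place of a group of three heavy atoms (one carbon, two nitrogen; no ring) on an amine nitrogen whose other neighbour is a saturated chain carbon. Going by the values given here, no pair of measured compounds in this set separates the effect of such an exchange, so any expectation rests on the change itself. The author expects the step from compound 2 to compound 3 to lead to a higher number, a 2.4-fold higher number from compound 2 to compound 3 (0.38 log units; beyond the scatter), of a size somewhat beyond the scatter. Compound 3 is accordingly estimated at 4000 nM, within a range from 1200 nM to 15000 nM.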

Compound 3, half-maximal inhibitory concentration: 890 nM
Compound 3: middle estimate off by 4.5-fold (0.65 log units), on the high side, outside the stated range (below it).
By their numbers in this assay, from the lowest: compound 1; then compounds 3 and 2 (each within the scatter of the next).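

In this assay, carbamoyl in place of a group of 3 heavy atoms (1 carbon, 2 nitrogen; no ring), on an amine nitrogen whose other neighbours are a saturated chain carbon, gives a 1.9-fold lower number from compound 2 to compound 3 (0.27 log units; within the scatter). Compounds 1 and 2 carry the same group at this place and could say nothing about an exchange there; this single step shows that, on the core of compound 2, carbamoyl can stand in that place without a shift in the number that exceeds the usual scatter, even though the entering group differs in its atoms and counts one hydrogen-bond donor fewer. No measurement is available that would explain this result.

On these data alone, whether carbamoyl would be tolerated in the same way on the core of compound 1 remains open, as this exchange is seen on one core only. Also open, as far as these compounds go, is what other groups on this amine nitrogen, such as acetyl or methyl, would give in this assay, and whether a shorter or longer chain carrying the amine nitrogen would alter the picture.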